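An Oxolanyl Tail in Place of a Dimethylamino Chain

The compounds below may be only part of what the source reports. "The series", "measured", "known", "first", "only" and "open" are said of these compounds alone.

Three compounds share one core and differ only in the group carried by the amine nitrogen in the ring. Compound 1 `Cc1cccc2sc(NC(=O)CCN3CCN(C(C)C)CC3)nc12` carries an isopropyl there, and in an assay on membranes from liver for displacement of a labelled ligand from Sigma intracellular receptor 2 (Rattus norvegicus), read by scintillation counting, with a stated time of 120 min (a lower number here means a stronger inhibitor, a higher number a weaker inhibitor), compound 1 gives 1800 nM. Compound 2 `Cc1cccc2sc(NC(=O)CCN3CCN(CCN(C)C)CC3)nc12` carries a 2-(dimethylamino)ethyl instead. In this assay compound 2 gives only a limit of the assay, > 1000 nM, not a number. Compound 3 `Cc1cccc2sc(NC(=O)CCN3CCN(CCCN(C)C)CC3)nc12` carries a 3-(dimethylamino)propyl. In this assay compound 3 likewise gives only a limit, > 1000 nM. Because the limit of > 1000 nM in this assay, at which 2 of the 3 values shown sit, the steps a step that the limit leaves unreadable from compound 1 to compound 2 and a step that the limit leaves unreadable from compound 1 to compound 3 cannot be sized, and the step that the two limits leave unreadable from compound 2 to compound 3 is unreadable as well. Compound 2 thus stands at the limit, with no readable distance to either neighbour.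

Compound 4 `Cc1cccc2sc(NC(=O)CCN3CCN(CC4CCCO4)CC3)nc12` is the unmeasured compound. It differs from compound 2 by oxolan-2-yl in place of (dimethylamino)methyl on a saturated chain carbon bound to an amine nitrogen in a ring. Within the data shown here, no measured step touches this change, and the three steps that exist are all unreadable, so neither size nor direction of the step in this assay can be foreseen from these data. The estimate therefore stays near what compound 1 shows at 1800 nM, with a wide range. Compound 4 is expected to give 1500 nM, between 300 nM and 8000 nM. The expected step that the limit leaves unreadable from compound 2 to compound 4 is accordingly an estimate of no particular size.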

Compound 4, inhibition constant: 5000 nM
Estimate against measurement, compound 4: 3.3-fold (0.52 log units) below, and the stated range covers the measured number.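

In this assay, this position on the amine nitrogen in the ring now has its first readable step, a 2.8-fold higher number from compound 1 to compound 4 (0.44 log units; beyond the scatter). Compound 4 is therefore a weaker inhibitor than compound 1, though only modestly, and the step shows that replacing isopropyl with (oxolan-2-yl)methyl does change the result by more than the usual scatter. The change from either dimethylamino chain to the oxolanyl tail still has no size or direction, and the steps from compound 2 and from compound 3 to compound 4 cannot be read because the values of compound 2 and compound 3 are limits: the limit of > 1000 nM in this assay, at which 2 of the 4 values shown sit.

The compounds shown leave open whether the ring itself or its oxygen goes with the weaker result, a question that a cyclopentylmethyl group, with an all-carbon five-membered ring, could help to settle. They also leave open how a chain ending in a morpholine ring would compare with the oxolanyl tail, and where the two dimethylamino chains truly stand.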